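The source may hold more compounds than are shown below. What is called first, only, known or untested is meant among the compounds shown, and "the series" means these compounds.

Within a functional assay on MCF7 cells (Homo sapiens) for antiproliferative activity, read by MTT assay, with a stated time of 48 h (a lower number here means a stronger inhibitor, a higher number a weaker inhibitor), compound 1 `O=c1cc(-n2cc(COc3ccccc3)nn2)c2cc(Br)ccc2o1` holds the lowest of the three numbers, giving 1720 nM. Compound 3 `O=c1cc(-n2cc(COc3ccc(Br)cc3)nn2)c2cc(Br)ccc2o1`, the 4-bromophenyl analogue, gives 1920 nM, and a 1.1-fold higher number from compound 1 to compound 3 (0.05 log units; within the scatter). Compound 2 `O=c1cc(-n2cc(COc3ccccc3Br)nn2)c2cc(Br)ccc2o1`, the 2-bromophenyl analogue, gives 28900 nM; a 17-fold higher number from compound 1 to compound 2 (1.23 log units; beyond the scatter), and a 15-fold lower number from compound 2 to compound 3 (1.18 log units; beyond the scatter). Compound 4 `O=c1cc(-n2cc(COc3ccc(F)cc3)nn2)c2cc(Br)ccc2o1` differs from compound 1 by fluoro in place of hydrogen on an aromatic carbon. For the measured compounds named here, the nearest precedent is the bromo in place of hydrogen step to the 4-bromophenyl analogue, compound 3, which stayed within the scatter; the 2-bromophenyl step concerns a different place and does not carry over. No shift beyond the scatter is therefore expected, and compound 4 is estimated at 1900 nM (range 900 nM to 4000 nM), which means a 1.1-fold higher number from compound 1 to compound 4 (0.04 log units; within the scatter).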

Compound 4, half-maximal inhibitory concentration: 7000 nM
Beside the measured number, compound 4's estimate is 3.7-fold (0.57 log units) below it; the measured number lies above the stated range.
By their numbers in this assay, from the lowest: compounds 1 and 3 (each within the scatter of the next); then compound 4; then compound 2.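

In this assay, the 4-position of the phenoxy ring proves sensitive to the choice of halogen: fluoro in place of hydrogen gives a 4.1-fold higher number from compound 1 to compound 4 (0.61 log units; beyond the scatter), and fluoro in place of bromo gives a 3.6-fold higher number from compound 3 to compound 4 (0.56 log units; beyond the scatter), although bromo in place of hydrogen at this place stayed within the scatter. Moving from 2-bromophenyl to 4-fluorophenyl gives a 4.1-fold lower number from compound 2 to compound 4 (0.62 log units; beyond the scatter), so compound 4 keeps a clear margin over compound 2. No measured evidence accounts for the difference between fluoro and bromo here. As far as these compounds go, how chloro, methoxy or an amine at this place would compare with hydrogen remains open.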